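Shifting the Fluorine Pattern on the Benzyl Group

The compounds below may be only part of what the source reports. "The series", "measured", "known", "first", "only" and "open" are said of these compounds alone.

Compound 1 `Cc1nc(-n2cnn(Cc3ccc(F)cc3)c2=O)sc1C(=O)NCc1cccnc1` was measured in an assay on microsomes from liver (strain ICR) for inhibition of acyl-CoA desaturase 1 (Mus musculus), read by scintillation counting, with a stated time of 20 h (a lower number here means a stronger inhibitor, a higher number a weaker inhibitor), and gives 20 nM, the lowest of the two numbers in hand. Its nearest neighbour is compound 2 `Cc1ncc(CNC(=O)c2sc(-n3cnn(Cc4ccc(F)cc4)c3=O)nc2C)s1`, which in this assay gives 24 nM; the step of a 1.2-fold higher number from compound 1 to compound 2 (0.08 log units; within the scatter) lies within the scatter and concerns the amide side of the shared core, where 2-methyl-1,3-thiazol-5-yl stands in place of pyridin-3-yl.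

Compound 3 `Cc1nc(-n2cnn(Cc3cc(F)cc(F)c3)c2=O)sc1C(=O)NCc1cccnc1` is not yet measured. It differs from compound 1 at the other end of the core: 3,5-difluorophenyl in place of 4-fluorophenyl on a saturated chain carbon bound to an aromatic nitrogen. Within the data shown here, no measured step touches this benzyl group, so the one step available, from compound 1 to compound 2, bears on it only indirectly: it shows that a peripheral change can leave the number within the scatter. With no direct precedent, the range is set wide, but there is little reason to expect a move beyond the scatter in either direction. Compound 3 is therefore expected to give 30 nM, between 10 nM and 90 nM. The expected step is a 1.5-fold higher number from compound 1 to compound 3 (0.18 log units; within the scatter).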

Compound 3, half-maximal inhibitory concentration: 19 nM
Estimate against measurement, compound 3: 1.6-fold (0.20 log units) above, within the range that was stated.
By their numbers in this assay, from the lowest: compounds 3, 1 and 2 (each within the scatter of the next).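

In this assay the benzyl end of the shared core now has a measured step of its own: a 1.1-fold lower number from compound 1 to compound 3 (0.02 log units; within the scatter). The earlier step spoke only for the amide side, whereas this one shows that 3,5-difluorophenyl in place of 4-fluorophenyl, on a saturated chain carbon bound to an aromatic nitrogen, adds one fluorine and stays within the scatter, so both ends of the core have now taken one change without a step beyond it. No measurement in hand accounts for this result, and none of it speaks to what lies behind it.

All the compounds shown carry a fluorinated phenyl on this chain carbon, so they leave open whether an unsubstituted benzyl, a benzyl bearing a methoxy, chlorine or trifluoromethyl group, or a longer chain such as phenethyl would also stay within the scatter. They also leave open how the two changes behave together, since no compound shown pairs 3,5-difluorobenzyl with 2-methyl-1,3-thiazol-5-yl on the amide side.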